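The source may report more compounds than this note shows. Statements on the series, on what has been measured and on what is new or still open speak of the compounds shown alone.

Of the compounds shown here, two built on the same core have been tested in an ADME assay on MCF7 cells (Homo sapiens) for inhibition (a lower number here means a stronger inhibitor, a higher number a weaker inhibitor), and neither returned a number. Compound 1 `COC(=O)c1cc2c(F)c(F)c(-n3cnc4ccccc43)c(F)c2s1` gives > 12000 nM, which is a limit of the assay. From the compounds shown here alone, compound 2 `O=C(c1ccccc1)c1cc2c(F)c(F)c(-n3ccnc3)c(F)c2s1` gives > 60000 nM, which is likewise only a limit, so its true position is unknown. Compound 3 `O=C(c1ccccc1)c1cc2c(F)c(F)c(-n3cnc4ccccc43)c(F)c2s1` differs from compound 2 at one place: 1H-benzimidazol-1-yl in place of 1H-imidazol-1-yl on an aromatic carbon, on an aromatic carbon ortho to two fluoro groups. Among the measured compounds shown here, no measured step shows what this exchange does. Compound 1 already carries 1H-benzimidazol-1-yl and reaches only its limit of > 12000 nM, so weak inhibition is expected to persist. The expected change is small and towards stronger inhibition, an at least 2.0-fold lower number from compound 2 to compound 3 (0.30 log units; that floor lies within the scatter). For compound 3 the estimated value is 30000 nM, with an expected range from 10000 nM to 80000 nM.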

Compound 3, half-maximal inhibitory concentration: > 25000 nM
Compound 3: no number, only a limit (the forecaster's own chance of this, stated with the estimate: 70%); the middle value does not contradict the limit.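

Compound 1, compound 2 and compound 3 all return only limits, not numbers, so no step can be read from compound 2 to compound 3 or from compound 1 to compound 3. The compounds shown leave open where the true values lie and what either exchange does to inhibition.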